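The source may report more compounds than this note shows. Statements on the series, on what has been measured and on what is new or still open speak of the compounds shown alone.

Compound 1 `COc1ccccc1C1CCN(c2ccn3c(CC4CC4)nnc3c2Cl)CC1` gives 345% in a functional assay on CHO cells for agonist activity at metabotropic glutamate receptor 2 (Homo sapiens), read by scintillation counting and GTPgammaS binding, with a stated time of 30 min; on this read-out higher numbers stand for larger maximal responses and lower numbers for smaller maximal responses. Compound 2 `COc1c(F)cccc1C1CCN(c2ccn3c(CC4CC4)nnc3c2Cl)CC1` gives 336%, and compound 3 `COc1c(F)ccc(F)c1C1CCN(c2ccn3c(CC4CC4)nnc3c2Cl)CC1` gives 282%. Compound 3 stands lowest of the three: its number lies a number 54 percentage points lower from compound 2 to compound 3 (beyond the scatter) and a number 63 percentage points lower from compound 1 to compound 3 (beyond the scatter), both beyond the scatter. The first fluoro brought a number 9 percentage points lower from compound 1 to compound 2 (within the scatter), within the scatter, so the drop appears only with the second fluoro.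

Compound 4 `COc1cc(F)cc(F)c1C1CCN(c2ccn3c(CC4CC4)nnc3c2Cl)CC1` keeps the same atoms as compound 3 but joins them differently: 2,4-difluoro-6-methoxyphenyl in place of 3,6-difluoro-2-methoxyphenyl on a saturated ring carbon. Going by the values given here, no measured step covers such a rearrangement of two fluorines on the ring. Among the compounds with values here, the steps that bear on it, from compound 1 and compound 2 to compound 3, show that the response depends on where fluorines sit, so moving them could shift the number either way. Because a number 54 percentage points lower from compound 2 to compound 3 (beyond the scatter) is large, a partial return toward compound 2 is taken as the more likely outcome, with wide uncertainty. Compound 4 is therefore expected to give 305%, ranging from 250% to 355%. That estimate means an expected a number 23 percentage points higher from compound 3 to compound 4 (beyond the scatter).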

Compound 4, largest response reached (Emax), in percent of the reference or control that the assay uses: 256%
Compound 4: the middle estimate sits 49 percentage points above what was measured; the range from low to high includes it.
By their numbers in this assay, from the lowest: compound 4; then compound 3; then compounds 2 and 1 (each within the scatter of the next).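

Keeping the same atoms and only rearranging them still moves the maximal response in this assay: 2,4-difluoro-6-methoxyphenyl in place of 3,6-difluoro-2-methoxyphenyl gives a number 26 percentage points lower from compound 3 to compound 4 (beyond the scatter). The gaps to the less fluorinated compounds widen as well, with a number 80 percentage points lower from compound 2 to compound 4 (beyond the scatter) and a number 89 percentage points lower from compound 1 to compound 4 (beyond the scatter), so among these four compounds the placement of the two fluorines matters, and not only their presence. Nothing available here explains why this arrangement gives the lowest number.

Still open, on these data alone, is how the response would move if chloro or methyl took the place of a fluoro, or ethoxy the place of the methoxy, on this phenyl ring. These numbers also describe only the largest response reached, not the concentration needed to reach it.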